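The source may report more compounds than this note shows. Statements on the series, on what has been measured and on what is new or still open speak of the compounds shown alone.

Compound 1 `CCC1C(=O)N(C)c2cnc(-n3ccc4cc(C(=O)NC)ccc43)nc2N1c1ccn(C)n1` gives 13300 nM in a functional assay on K562 cells (Homo sapiens) for antiproliferative activity, read by CCK-8 assay, with a stated time of 72 h; on this read-out higher numbers stand for weaker inhibition of growth and lower numbers for stronger inhibition of growth. Compound 2 `CCC1C(=O)N(C)c2cnc(Nc3ccc(S(=O)(=O)NCCCO)cc3)nc2N1c1ccn(C)n1` gives 13400 nM. Compound 3 `CCC1C(=O)N(C)c2cnc(Nc3ccc(S(=O)(=O)NCC(C)C)cc3)nc2N1c1ccn(C)n1` gives 7300 nM.

Of the three numbers, that of compound 3 is the lowest, yet compound 1 and compound 2 each sit within the scatter of it, so the three compounds cannot be separated on these data. Compound 4 `CCCCNS(=O)(=O)c1ccc(Nc2ncc3c(n2)N(c2ccn(C)n2)C(CC)C(=O)N3C)cc1` differs from compound 3 in one place: propyl in place of isopropyl on a saturated chain carbon bound to a sulfonamide nitrogen. Within the data shown here, the only measured step at this position is a 1.8-fold lower number from compound 2 to compound 3 (0.26 log units; within the scatter), which stayed within the scatter. A rearrangement of the same three carbons is therefore expected to produce no step beyond the scatter in this assay, no change at the digits printed from compound 3 to compound 4 (within the scatter). Compound 4 is accordingly estimated at 7300 nM, with a range from 3500 nM to 15000 nM.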

Compound 4, concentration for 50% growth inhibition: 4240 nM
Estimate against measurement, compound 4: 1.7-fold (0.24 log units) above, and the stated range covers the measured number.
By their numbers in this assay, from the lowest: compounds 4, 3, 1 and 2 (each within the scatter of the next, the first and the last beyond it).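

In this assay this position gives its first step beyond the scatter, the modest 3.2-fold lower number from compound 2 to compound 4 (0.50 log units; beyond the scatter), with methyl in place of hydroxy on a saturated chain carbon, three bonds along the chain from a sulfonamide nitrogen. The other step, a 1.7-fold lower number from compound 3 to compound 4 (0.24 log units; within the scatter), shows that propyl and isopropyl cannot be separated here. No measurement given here accounts for either step.

Still open, going by these compounds, is how a longer chain, an amine or a carboxylic acid at this position would compare with the butylsulfamoyl group of compound 4.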